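Dithiocarbamate series: every reading so far at the assay limit

A few compounds are considered here, and "the series" means these few. Any claim that something is new, unique, unknown or untested is made for them only; others in the source may bear on it.

Three compounds have been run in a functional assay on PC-3 cells (Homo sapiens) for inhibition, read by MTT assay, with a stated time of 72 h; a higher number here means a weaker inhibitor, a lower number a stronger inhibitor. For the measured compounds named here, compound 1 `O=C(OCc1ccccc1)N1CCN(C(=S)SCc2cn(Cc3ccc(Cl)cc3)nn2)CC1` is the first. In this assay compound 1 returns only a limit, > 128000 nM. Compound 2 `COc1ccc(Cn2cc(CSC(=S)N3CCN(C(=O)OCc4ccccc4)CC3)nn2)cc1` differs from it by chloro in place of methoxy on an aromatic carbon. In this assay compound 2 likewise gives only a limit, > 128000 nM. Compound 3 `COc1ccc(Cn2cc(CSC(=S)N3CCN(C(=O)OC(C)(C)C)CC3)nn2)cc1` differs from compound 2 by tert-butyl in place of benzyl on an oxygen next to a carbonyl group. In this assay compound 3 also stands at a limit, > 128000 nM.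

Neither step can be sized: a step that the two limits leave unreadable from compound 2 to compound 1 and a step that the two limits leave unreadable from compound 2 to compound 3 both run between two limits. The one firm point shared by the three is the limit of > 128000 nM in this assay, at which 3 of the 3 values shown sit.

Compound 4 `CC(C)(C)OC(=O)N1CCN(C(=S)SCc2cn(Cc3ccc(Cl)cc3)nn2)CC1` is not yet measured. It differs from compound 3 by chloro in place of methoxy on an aromatic carbon. The place is described in the same words as for the change from compound 2 to compound 1, so this is the same change, now made on the core of compound 3; the two cores differ only by the change from compound 2 to compound 3 already described.

Because the limit of > 128000 nM in this assay, at which 3 of the 3 values shown sit, holds both compound 2 and compound 1, the earlier occurrence of this change gave no readable movement, and the step from compound 3 to compound 4 is expected to be a step that the limit leaves unreadable from compound 3 to compound 4. Compound 4 is expected near 250000 nM, estimated between 120000 nM and 800000 nM, and most likely to be reported as a limit again.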

Compound 4, half-maximal inhibitory concentration: > 128000 nM
Compound 4 was reported as a limit; the forecaster's own chance of this, stated with the estimate: 85%; the middle value lies beyond the limit too.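

Neither new step can be read: the steps linking compound 4 to compound 3 and to compound 1 run between two limits, and the series stays at one shared limit: the limit of > 128000 nM in this assay, at which 4 of the 4 values shown sit.

The compounds shown leave open how far any of the four lies beyond that limit, and whether chloro in place of methoxy or tert-butyl in place of benzyl changes inhibition at all in this assay.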